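This account rests on a few compounds, and the source may have more. Where it says the series, first, only, none or still open, it means among the compounds named here.

Measured so far in a functional assay on B16 cells (Mus musculus) for cytotoxicity, read by CCK-8 assay, with a stated time of 24 h; a higher number here means a weaker inhibitor, a lower number a stronger inhibitor:

- compound 1 `COc1ccccc1Oc1c(N)nc(-c2cccc(F)c2)nc1OCCO` gives 20900 nM
- compound 2 `COc1ccccc1Oc1c(N)nc(-c2cccc(Br)c2)nc1OCCO` gives 21900 nM

With only these two numbers, compound 2 stands level with compound 1, within the scatter, so neither can be ranked above the other. The next compound to be tested is compound 3 `COc1ccccc1Oc1c(N)nc(-c2ccc(Br)cc2)nc1OCCO`. It has the same atoms as compound 2, joined differently, with 4-bromophenyl in place of 3-bromophenyl on an aromatic carbon. That carbon lies between two ring nitrogen atoms of the shared core.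

Among the measured compounds shown here, only one measured step bears on this change, and only indirectly. It is a 1.0-fold higher number from compound 1 to compound 2 (0.02 log units; within the scatter), for bromo in place of fluoro on an aromatic carbon. For the measured compounds named here, that step shows no response to a change of halogen, but no measured step tests a move of the halogen itself, so the evidence is thin. No shift beyond the scatter is therefore expected in this assay, and no direction is favoured. The expected step is a 1.0-fold lower number from compound 2 to compound 3 (0.02 log units; within the scatter). For compound 3 the estimate is 21000 nM, with an expected range from 11000 nM to 42000 nM.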

Compound 3, half-maximal inhibitory concentration: 11800 nM
The estimate for compound 3 lay 1.8-fold (0.25 log units) above the measured number, and the stated range covers the measured number.
By their numbers in this assay, from the lowest: compounds 3, 1 and 2 (each within the scatter of the next).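

Moving the bromine from 3-bromophenyl to 4-bromophenyl on the aromatic carbon between two ring nitrogen atoms gives a 1.9-fold lower number from compound 2 to compound 3 (0.27 log units; within the scatter) in this assay and is the first test of where the halogen sits on this ring, whereas the earlier step tested only which halogen is present. Changing the halogen and its place together gives a 1.8-fold lower number from compound 1 to compound 3 (0.25 log units; within the scatter) and likewise stays within the scatter, so neither edit to this aryl group, alone or combined, has yet moved the number beyond the scatter in this assay and the three compounds cannot be ranked. No supporting evidence is available to interpret these small steps any further.

From the compounds shown here alone, whether this position responds to anything other than a halogen on the phenyl ring remains open, for instance a carboxylic acid, an amine or a nitrile in place of the bromine. Also open, going by these compounds, is whether a longer chain in place of the 2-hydroxyethoxy group, or a different group in place of the 2-methoxyphenoxy group, would shift the number beyond the scatter.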